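This account rests on a few compounds, and the source may have more. Where it says the series, first, only, none or still open, it means among the compounds named here.

Compound 1 `Cc1cc(NC(=O)Cn2cc(-c3cccc(Cl)c3)nn2)no1`, compound 2 `Cc1cc(NC(=O)Cn2cc(-c3ccccc3Cl)nn2)no1` and compound 3 `O=C(Cn1cc(-c2cccs2)nn1)Nc1nccs1` share an amide-linked triazole framework and were tested in a functional assay on BMDM cells (Mus musculus, strain C57BL/6) for inhibition, with a stated time of 2 days; a lower number here means a stronger inhibitor, a higher number a weaker inhibitor. Compound 1 gives in this assay only a limit of > 30000 nM, not a number. Compound 2 likewise reaches only a limit in this assay, at > 30000 nM. The change of 2-chlorophenyl in place of 3-chlorophenyl on an aromatic carbon therefore gives a step that the two limits leave unreadable from compound 1 to compound 2. Compound 3 stands no differently: in this assay compound 3 shows only a limit, > 30000 nM, and every value in this set is a limit, as the limit of > 30000 nM in this assay, at which 3 of the 3 values shown sit, records.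

Compound 4 `Cc1cc(NC(=O)Cn2cc(-c3cccs3)nn2)no1` differs from compound 3 by 5-methyl-1,2-oxazol-3-yl in place of 1,3-thiazol-2-yl on an amide-type nitrogen. Going by the values given here, no measured step touches the amide-type nitrogen, so no step bears directly on this change; the only comparison concerns the aromatic carbon and is unreadable. Compound 1 and compound 2, which carry the 5-methyl-1,2-oxazol-3-yl group entering here, both sit at the limit. Compound 4 is therefore expected to remain at or near the limit, with an estimated 30000 nM, between 8000 nM and 100000 nM, which means an expected step of a number no higher from compound 3 to compound 4 (the limit leaves the size open).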

Compound 4, half-maximal inhibitory concentration: > 30000 nM
Compound 4: a limit, no number; the forecaster's own chance of this, stated with the estimate: 85%; the middle value sits exactly at the limit.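

In this assay compound 4 gives only a limit, > 30000 nM, not a number, so its steps from compound 1, compound 2 and compound 3 cannot be read. The compounds shown leave open how any of these changes affects inhibition, as all share one limit: the limit of > 30000 nM in this assay, at which 4 of the 4 values shown sit.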